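Swapping the Ester Alkyl Group: Compound 3 to Compound 4

The compounds below may be only part of what the source reports. "The series", "measured", "known", "first", "only" and "open" are said of these compounds alone.

Of the compounds shown here, three sharing one core have been measured in an assay on membranes from HeLa cells for displacement of a labelled ligand from adenosine receptor A3 (Homo sapiens), read by scintillation counting, with a stated time of 180 min, tested at 1 uM; on this read-out lower numbers stand for less inhibition and higher numbers for more inhibition at the one concentration tested (going by the name of the read-out). Compound 1 `CCNC(=O)C1=C(C)NC(=O)NC1c1cccs1` gives 4%, compound 2 `CCN(CC)C(=O)C1=C(C)NC(=O)NC1c1cccs1` gives 31%, and compound 3 `CC1=C(C(=O)OC2CCCC2)C(c2cccs2)NC(=O)N1` gives 1%. Compound 3 sits at the low end of the three alongside compound 1, the two within the scatter of each other, while the step of a number 30 percentage points lower from compound 2 to compound 3 (beyond the scatter) lies beyond it. The steps of a number 27 percentage points higher from compound 1 to compound 2 (beyond the scatter) and a number 3 percentage points lower from compound 1 to compound 3 (within the scatter) complete the picture: only the diethylamino compound rises clearly.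

Compound 4 `CC1=C(C(=O)OCC2CC2)C(c2cccs2)NC(=O)N1` differs from compound 3 by cyclopropylmethyl in place of cyclopentyl on an oxygen next to a carbonyl group. Going by the values given here, no measured step alters the alkyl group on the ester oxygen; the two steps that reach compound 3 exchange an amide for an ester and so do not bear directly on this change. With compound 3 already near the bottom of the read-out, a step of a number 2 percentage points higher from compound 3 to compound 4 (within the scatter) in this assay is expected, that is, none beyond the scatter. Compound 4 is therefore estimated at 3% in this assay, with a range from -8% to 15%.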

Compound 4, a percentage reported as inhibition, at one concentration (the size of the read-out at that concentration, not a potency): 1%
The estimate for compound 4 lay 2 percentage points above the measured number; the range from low to high includes it.
By their numbers in this assay, from the lowest: compounds 3, 4 and 1 (each within the scatter of the next); then compound 2.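

In this assay, going by these compounds alone, this is the first step that alters the alkyl group on the ester oxygen, and cyclopropylmethyl in place of cyclopentyl gives no change at the digits printed from compound 3 to compound 4 (within the scatter), so this swap at this position leaves the read-out where it stood. The second ester also behaves like the first against the two amides, with a number 30 percentage points lower from compound 2 to compound 4 (beyond the scatter) but a number 3 percentage points lower from compound 1 to compound 4 (within the scatter), which leaves the diethylamino compound alone in standing apart from the other three compounds. No supporting evidence is available to explain why the ester swap leaves the read-out unmoved.

Still open, from the compounds shown here alone, is whether any group on this ester oxygen can lift the read-out, such as benzyl, a longer chain or a chain ending in an amine or a carboxylic acid. Also open, going by these compounds, is whether a cyclic amide such as the piperidine amide would match the rise seen with diethylamino.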